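Swapping phenyl for dichlorophenoxy in a weak nicotinic antagonist

This account rests on a few compounds, and the source may have more. Where it says the series, first, only, none or still open, it means among the compounds named here.

Compound 1, `CC1CC(=O)N(c2ccccc2C(=O)OCC2CCCN(CCCCCc3ccccc3)C2)C1=O`, gives 24500 nM in an in vitro functional assay on HEK ts201 cells for antagonist activity at Neuronal acetylcholine receptor; alpha4/beta2 (Homo sapiens), read by fluorescence and calcium flux; a lower number here means a stronger inhibitor, a higher number a weaker inhibitor.
Compound 2, `O=C(Nc1ccccn1)c1ccccc1-c1ccccc1`, gives 13600 nM in this assay.
Compound 3, `c1ccc(CCCN2CCCC(COCc3ccccc3-c3ccccc3)C2)cc1`, gives 12600 nM in this assay.

Compound 1 has the highest number of the three, but its gaps to compound 2 and to compound 3 both fall within the usual scatter, so the three stand together as weak inhibitors. No two of the measured compounds differ in only one place, so no step size can be read from them. Compound 4, `CC1CC(=O)N(c2ccccc2C(=O)OCC2CCCN(CCCCCOc3ccc(Cl)c(Cl)c3)C2)C1=O`, differs from compound 1 by 3,4-dichlorophenoxy in place of phenyl on a saturated chain carbon, five bonds along the chain from an amine nitrogen in a ring. With nothing measured along this path, the step expected in this assay is small, none beyond the scatter. Compound 4 is estimated at 15000 nM, between 4000 nM and 50000 nM. That estimate means a step of a 1.6-fold lower number from compound 1 to compound 4 (0.21 log units; within the scatter) in this assay.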

Compound 4, half-maximal inhibitory concentration: 17400 nM
Compound 4: the middle estimate sits 1.2-fold (0.06 log units) below what was measured; the range from low to high includes it.
By their numbers in this assay, from the lowest: compounds 3, 2, 4 and 1 (each within the scatter of the next).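

At this place, on a saturated chain carbon, five bonds along the chain from an amine nitrogen in a ring, 3,4-dichlorophenoxy stands in for phenyl with a step of a 1.4-fold lower number from compound 1 to compound 4 (0.15 log units; within the scatter) in this assay, which lies within the scatter. The swap adds oxygen and chlorine to the group, yet compound 4 remains a weak inhibitor, like compound 1. No outside measurement bears on this result.

Plain phenoxy at this place would separate the oxygen from the chlorines, and that comparison stays open. Also open, from the compounds shown here alone, is whether a carboxylic acid or an amine here would give a step beyond the scatter.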